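The compounds below may be only part of what the source reports. "The series", "measured", "known", "first", "only" and "open" are said of these compounds alone.

Measured in a functional assay on A549 cells (Homo sapiens) for antiproliferative activity, read by MTT assay; a higher number here means a weaker inhibitor, a lower number a stronger inhibitor:
compound 1 `Cn1c(=O)c(=O)n(C2CCCC2)c2nc(N/N=C/c3ccc(Cl)cc3)ncc21`: 6890 nM
compound 2 `Cn1c(=O)c(=O)n(C2CCCC2)c2nc(N/N=C/c3ccc(S(C)(=O)=O)cc3)ncc21`: 84500 nM
compound 3 `Cn1c(=O)c(=O)n(C2CCCC2)c2nc(N/N=C/c3ccc(C(F)(F)F)cc3)ncc21`: 40600 nM

Compound 3, at 40600 nM, holds the middle place of these three. Compound 4 `Cn1c(=O)c(=O)n(C2CCCC2)c2nc(N/N=C/c3ccco3)ncc21` differs from it by furan-2-yl in place of 4-(trifluoromethyl)phenyl on a carbon with a double bond to nitrogen. Among the measured compounds shown here, no measured step makes this exchange. The nearest guides only swap the group on the aromatic carbon: the modest 5.9-fold higher number from compound 1 to compound 3 (0.77 log units; beyond the scatter) and the modest 2.1-fold lower number from compound 2 to compound 3 (0.32 log units; beyond the scatter), and the large 12-fold higher number from compound 1 to compound 2 (1.09 log units; beyond the scatter) shows how wide the series runs. A modest move toward a lower number is therefore expected, but with little certainty. The expected step is a 2.0-fold lower number from compound 3 to compound 4 (0.31 log units; beyond the scatter). For compound 4 the estimate is 20000 nM, with an expected range from 6000 nM to 70000 nM.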

Compound 4, half-maximal inhibitory concentration: > 100000 nM
Compound 4 was reported as a limit; the forecaster's own chance of this, stated with the estimate: 5%; at least 5.0-fold (0.69 log units) between middle value and limit.
By their numbers in this assay, from the lowest: compound 1; then compound 3; then compound 2. At a limit, above all of these: compound 4.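

Compound 4 is reported only as a limit: the limit of > 100000 nM in this assay, at which 1 of the 4 values shown sits. Furan-2-yl on the carbon with a double bond to nitrogen gives an at least 2.4-fold higher number from compound 3 to compound 4 (0.39 log units; beyond the scatter), an at least 14-fold higher number from compound 1 to compound 4 (1.16 log units; beyond the scatter) and an at least 1.1-fold higher number from compound 2 to compound 4 (0.07 log units; that floor lies within the scatter). The first two steps show that this five-membered ring brings no gain over the 4-(trifluoromethyl)phenyl of compound 3 or the 4-chlorophenyl of compound 1, while the floor of the third lies within the scatter and sets no order against the 4-(methylsulfonyl)phenyl of compound 2.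

On these data alone, whether the loss goes with the smaller ring or with its oxygen stays open. So does the effect of thiophen-2-yl, or of a phenyl ring carrying an amine.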